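This account rests on a few compounds, and the source may have more. Where it says the series, first, only, none or still open, it means among the compounds named here.

Three related sulfonamide amines have been tested in a functional assay on MIA PaCa-2 cells (Homo sapiens) for inhibition, read by MTT assay, with a stated time of 72 h; a lower number here means a stronger inhibitor of growth, a higher number a weaker inhibitor of growth. Compound 2 `O=S(=O)(NCCCNCC1COc2ccccc2O1)c1cc(C(F)(F)F)cc(C(F)(F)F)c1` gives 2600 nM there. Within the data shown here, compound 1 `O=S(=O)(NCCNCc1ccc(-c2ccccc2)cc1)c1cc(C(F)(F)F)cc(C(F)(F)F)c1` gives 2700 nM, a number that sits within the usual scatter of the one for compound 2. Compound 3 `O=S(=O)(NCCCCCCNCc1ccc(Br)cc1)c1cccc(C(F)(F)F)c1` gives 5970 nM, a higher number that lies beyond the scatter from compound 2.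

Compound 4 `COc1ccc(CNCCCNS(=O)(=O)c2cc(C(F)(F)F)cc(C(F)(F)F)c2)cc1` has not yet been measured in this assay. It differs from compound 2 in one place: 4-methoxyphenyl in place of 2,3-dihydro-1,4-benzodioxin-2-yl on a saturated chain carbon bound to an amine nitrogen. Compounds 1 and 2 show that two rather different groups on that chain carbon give numbers within the scatter of each other. A modest change is therefore expected, if any, with a step from compound 2 to compound 4 of a 1.3-fold higher number from compound 2 to compound 4 (0.13 log units; within the scatter). Compound 4 is expected to give about 3500 nM, within a range from 1500 nM to 8000 nM.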

Compound 4, concentration for 50% growth inhibition: 2500 nM
For compound 4 the middle estimate is 1.4-fold (0.15 log units) above the measured one, and the stated range covers the measured number.
By their numbers in this assay, from the lowest: compounds 4, 2 and 1 (each within the scatter of the next); then compound 3.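

In this assay the swap to 4-methoxyphenyl from 2,3-dihydro-1,4-benzodioxin-2-yl gives a 1.0-fold lower number from compound 2 to compound 4 (0.02 log units; within the scatter) on a saturated chain carbon bound to an amine nitrogen. This is the first pair shown that differs in this one place only, and the entering group has one ring fewer, fewer heavy atoms and fewer hydrogen-bond acceptors, yet the number stays within the scatter. No measurement here gives a reason for this result.

Still open, as far as these compounds go, is how a carboxylic acid or a second amine on this carbon would fare. Also open, from the compounds shown here alone, is whether a longer chain would change the outcome of this swap.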